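The source may report more compounds than this note shows. Statements on the series, on what has been measured and on what is new or still open speak of the compounds shown alone.

Compound 1 `O=C(O)CC/C=C\CC1COC(c2ccc([N+](=O)[O-])cc2)OC1c1cccnc1` and compound 2 `O=C(O)CC/C=C\CC1COC(c2ccc(Cl)cc2Cl)OC1c1cccnc1` share a core that compound 3 `COc1ccc(OC(C)(C)C2OCC(C/C=C\CCC(=O)O)C(c3cccnc3)O2)cc1` carries further with a 4-methoxyphenoxy-bearing branch. In an assay for inhibition of prostacyclin synthase (Homo sapiens), using microsomes (on this read-out higher numbers stand for weaker inhibition and lower numbers for stronger inhibition), compound 1 gives 13000 nM, and compound 2 gives 2500 nM. Among the compounds with values here, the single measured step, a 5.2-fold lower number from compound 1 to compound 2 (0.72 log units; beyond the scatter), is the only guide to how an exchange of an aryl group moves this read-out. Compound 3 stands apart from both: in this assay compound 3 gives > 100000 nM, which is a limit of the assay and not a number, as recorded by the limit of > 100000 nM in this assay, at which 1 of the 3 values shown sits. Compound 4 `CC(C)(Oc1ccccc1Br)C1OCC(C/C=C\CCC(=O)O)C(c2cccnc2)O1` differs from compound 3 in one place: 2-bromophenyl in place of 4-methoxyphenyl on an oxygen on a saturated carbon. Within the data shown here, no measured step changes an aryl group on an oxygen; the one measured aryl exchange sits on a ring carbon and was modest. Compound 3 already sits at the limit, so the step of a number no higher from compound 3 to compound 4 (the limit leaves the size open) is expected to be small. Compound 4 is therefore expected to give about 100000 nM in this assay, with a range from 20000 nM to 500000 nM.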

Compound 4, half-maximal inhibitory concentration: 7000 nM
Compound 4: the middle estimate sits 14-fold (1.15 log units) above what was measured; the measured number lies below the stated range.
By their numbers in this assay, from the lowest: compound 2; then compounds 4 and 1 (each within the scatter of the next). At a limit, above all of these: compound 3.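

Exchanging 4-methoxyphenyl for 2-bromophenyl on an oxygen on a saturated carbon gives an at least 14-fold lower number from compound 3 to compound 4 (1.15 log units; beyond the scatter), so the aryl group at this position can move the read-out strongly. The earlier compounds shown here showed an aryl exchange only on a ring carbon, where the step was modest, and they gave no measured number for any compound carrying this branch. Compound 3 gives > 100000 nM, which is a limit of the assay and not a number, so the size of the new step is open on its upper side: the limit of > 100000 nM in this assay, at which 1 of the 4 values shown sits.

The compounds shown leave open whether the step follows the bromine, the loss of the methoxy group or the change in where the substituent sits on the ring. Plain phenyl, 2-methoxyphenyl or 4-bromophenyl on that oxygen would separate these readings.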